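Hydrazone aryl swap on the shared core: indole to hydroxynaphthyl

The compounds below may be only part of what the source reports. "The series", "measured", "known", "first", "only" and "open" are said of these compounds alone.

The series keeps the core of compound 1 `CCCSc1nc(N/N=C/c2cccnc2)c2nnn(Cc3ccccc3)c2n1` and varies the aryl group on the hydrazone carbon. In a functional assay on ECa-109 cells (Homo sapiens) for antiproliferative activity, read by MTT assay, with a stated time of 72 h (on this read-out higher numbers stand for weaker inhibition and lower numbers for stronger inhibition), compound 1 reaches only the limit > 64000 nM (the limit of > 64000 nM in this assay, at which 1 of the 3 values shown sits). Compound 3 `CCCSc1nc(N/N=C/c2c[nH]c3ccccc23)c2nnn(Cc3ccccc3)c2n1` gives 8690 nM in this assay, the nearest number being that of compound 2 `C#CCSc1nc(N/N=C/c2c(O)ccc3ccccc23)c2nnn(Cc3ccccc3)c2n1` at 6520 nM, the two within the scatter of each other. Going by the values given here, the step of an at least 7.3-fold lower number from compound 1 to compound 3 (0.86 log units; beyond the scatter) is the only measured change at this position. Compound 4 `CCCSc1nc(N/N=C/c2c(O)ccc3ccccc23)c2nnn(Cc3ccccc3)c2n1` brings (2-hydroxynaphthalen-1-yl in place of 1H-indol-3-yl on a carbon with a double bond to nitrogen). Among the compounds with values here, no measured step carries this same change; compound 2 bears the same entering group on a core differing elsewhere and sits within the scatter of compound 3. The step of a 1.2-fold lower number from compound 3 to compound 4 (0.09 log units; within the scatter) is therefore expected to stay within the scatter. Compound 4 is estimated at 7000 nM in this assay, range 3000 nM to 16000 nM.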

Compound 4, half-maximal inhibitory concentration: 9290 nM
Estimate against measurement, compound 4: 1.3-fold (0.12 log units) below; measured number inside the range.
By their numbers in this assay, from the lowest: compounds 2, 3 and 4 (each within the scatter of the next). At a limit, above all of these: compound 1.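

In this assay, the swap of the fused aryl group gives no separation: a 1.1-fold higher number from compound 3 to compound 4 (0.03 log units; within the scatter), so 2-hydroxynaphthalen-1-yl and 1H-indol-3-yl read alike at this position. A second group now clears pyridin-3-yl beyond the scatter: an at least 6.8-fold lower number from compound 1 to compound 4 (0.83 log units; beyond the scatter). The sulfur chain also gives no separation with the 2-hydroxynaphthalen-1-yl group in place: a 1.4-fold higher number from compound 2 to compound 4 (0.15 log units; within the scatter), a change of ethynyl to ethyl.

From the compounds shown here alone, compound 1 remains a limit, and the full size of its steps stays open: the limit of > 64000 nM in this assay, at which 1 of the 4 values shown sits. Also open is how an amine or a carboxylic acid on the hydrazone aryl group, or a longer chain on the sulfur, would read.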